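The source may report more compounds than this note shows. Statements on the series, on what has been measured and on what is new or still open speak of the compounds shown alone.

Measured so far:
compound 1 `O=C1/C(=C/c2ccccc2F)COC/C1=C\c1ccccc1Br` — 6500 nM
compound 2 `O=C1/C(=C/c2ccccc2)COC/C1=C\c1ccccc1F` — 17600 nM

In a functional assay on A549 cells (Homo sapiens) for cytotoxicity, read by MTT assay, with a stated time of 72 h (a lower number here means a stronger inhibitor, a higher number a weaker inhibitor), compound 2 stands highest of the two numbers; its nearest neighbour is compound 1, reached by a 2.7-fold higher number from compound 1 to compound 2 (0.43 log units; beyond the scatter). Compound 3 `O=C1/C(=C/c2ccccc2F)COC/C1=C\c1ccccc1C(=O)O` differs from compound 2 by carboxy in place of hydrogen on an aromatic carbon. Among the compounds with values here, the only measured step touches the same aromatic carbon but swaps bromo for hydrogen, a different group, so it bears on this change only loosely. Within the data shown here, no step with carboxy exists. The expectation for compound 3 is therefore a step of a 1.3-fold higher number from compound 2 to compound 3 (0.10 log units; within the scatter), uncertain in direction, with compound 3 estimated at 22000 nM (range 7000 nM to 70000 nM).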

Compound 3, half-maximal inhibitory concentration: 27900 nM
The estimate for compound 3 lay 1.3-fold (0.10 log units) below the measured number; the range from low to high includes it.
By their numbers in this assay, from the lowest: compound 1; then compounds 2 and 3 (each within the scatter of the next).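

In this assay, carboxy in place of hydrogen on this aromatic carbon gives a 1.6-fold higher number from compound 2 to compound 3 (0.20 log units; within the scatter) and so does not separate the two groups. Carboxy in place of bromo gives a 4.3-fold higher number from compound 1 to compound 3 (0.63 log units; beyond the scatter) and, of the three groups seen at this carbon, only bromo stands apart, with the lower number. No measurement available here explains this result.

Open, on these data alone, is whether chloro or iodo at this carbon would stay with bromo. Also open, as far as these compounds go, is whether an amine or a methyl ester would fall with hydrogen and carboxy.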